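Group swap on the carbonyl: compound 3 to compound 4

The source may report more compounds than this note shows. Statements on the series, on what has been measured and on what is new or still open speak of the compounds shown alone.

Values measured in a functional assay on C8166 cells (Homo sapiens) for cytotoxicity, read by MTT assay (on this read-out lower numbers stand for higher toxicity in this test and higher numbers for lower toxicity in this test), follow
- compound 1 `Cc1ccc(C(=O)Nc2cc(Cl)ccc2OCC(=O)Nc2ccc(S(N)(=O)=O)cc2C)c(C)c1` gives 47600 nM
- compound 2 `Cc1cc(C)cc(C(=O)Nc2cc(Cl)ccc2OCC(=O)Nc2ccc(S(N)(=O)=O)cc2C)c1` gives 36500 nM
- compound 3 `Cc1cc(S(N)(=O)=O)ccc1NC(=O)COc1ccc(Cl)cc1NC(=O)c1cc(Cl)cc(Br)c1` gives 114000 nM

Compound 3 stands highest of the three in this assay at 114000 nM and so shows the lowest toxicity in this test. All measured steps exchange the group on the same carbonyl carbon. They are a 2.4-fold higher number from compound 1 to compound 3 (0.38 log units; beyond the scatter) and a 3.1-fold higher number from compound 2 to compound 3 (0.49 log units; beyond the scatter) both modest and beyond the scatter, while a 1.3-fold lower number from compound 1 to compound 2 (0.12 log units; within the scatter) stays within it.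

Compound 4 (`Cc1cc(S(N)(=O)=O)ccc1NC(=O)COc1ccc(Cl)cc1NC(=O)/C=C/c1ccccc1`) changes that same place (2-phenylethenyl in place of 3-bromo-5-chlorophenyl on a carbonyl carbon). In words, 2-phenylethenyl comes in place of 3-bromo-5-chlorophenyl on a carbonyl carbon. Among the compounds with values here, no measured compound carries 2-phenylethenyl, so the measured steps bear on this change only indirectly. The entering group holds carbon only, like the dimethylphenyl groups of compound 1 (47600 nM) and compound 2 (36500 nM), so a move back toward those values is expected. The estimated step in this assay is modest and toward a lower number, namely a 2.1-fold lower number from compound 3 to compound 4 (0.32 log units; beyond the scatter) with considerable uncertainty. Compound 4 is estimated at 55000 nM with an expected range (24000 nM to 125000 nM).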

Compound 4, half-maximal cytotoxic concentration: 163000 nM
Compound 4: middle estimate off by 3.0-fold (0.47 log units), on the low side; measured number outside the range, above it.
By their numbers in this assay, from the lowest: compounds 2 and 1 (each within the scatter of the next); then compounds 3 and 4 (each within the scatter of the next).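

Working note on the group on the carbonyl carbon, in this assay: a 1.4-fold higher number from compound 3 to compound 4 (0.16 log units; within the scatter) lies within the scatter, whereas a 4.5-fold higher number from compound 2 to compound 4 (0.65 log units; beyond the scatter) and a 3.4-fold higher number from compound 1 to compound 4 (0.53 log units; beyond the scatter) are modest steps beyond it. Halogen atoms on the group are therefore not needed for compound 3 and compound 4 to stand together above compound 1 and compound 2, and a group of carbon only does not by itself give the lower numbers, as those two dimethylphenyl compounds alone might have suggested. Nothing shown accounts for 2-phenylethenyl grouping with 3-bromo-5-chlorophenyl rather than with the dimethylphenyl groups.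

The compounds shown leave open whether the double bond outside the aromatic ring matters, a question that 2-phenylethyl, the same group with a saturated chain, would address directly. Also open, on these data alone, is how far the numbers in this assay would shift with unsubstituted phenyl on the carbonyl carbon, or with a phenyl ring carrying an amine or a carboxylic acid, since every group here holds only carbon or halogen atoms besides hydrogen.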